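Exposure notes: bromo to cyano on the shared core

The compounds below may be only part of what the source reports. "The series", "measured", "known", "first", "only" and "open" are said of these compounds alone.

Compound 1 `COc1cc([C@](O)(CCN(C)C)[C@@H](c2cc3cc(C#N)ccc3nc2OC)c2cccc(OC)c2F)cc(SC)n1`: 1100 ng.h/mL
Compound 2 `CCSc1cc([C@](O)(CCN(C)C)[C@@H](c2cc3cc(Br)ccc3nc2OC)c2cccc(OC)c2F)cc(SCC)n1`: 11900 ng.h/mL

In an ADME assay on the whole organism (Mus musculus, strain CD-1) for pharmacokinetics, at a dose of 10 mg/kg by the oral route (on this read-out higher numbers stand for higher exposure at the dose given and lower numbers for lower exposure), compound 2 gives 11900 ng.h/mL, the higher of the two numbers, and its gap to compound 1 lies beyond the scatter. Compound 3 `CCSc1cc([C@](O)(CCN(C)C)[C@@H](c2cc3cc(C#N)ccc3nc2OC)c2cccc(OC)c2F)cc(SCC)n1` takes cyano in place of bromo on an aromatic carbon of compound 2 (cyano in place of bromo on an aromatic carbon). Within the data shown here, no measured pair isolates this change. The nearest guide is that compound 1 also carries cyano and gives 1100 ng.h/mL, but it differs from compound 2 in more than one place, so that gap cannot be assigned to cyano alone. A moderate fall in this assay is therefore expected, with a wide margin. The estimated change is a 2.4-fold lower number from compound 2 to compound 3 (0.38 log units; beyond the scatter). For compound 3 the expected value is 5000 ng.h/mL, with an estimated range of 1600 ng.h/mL to 14000 ng.h/mL.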

Compound 3, area under the concentration-time curve: 1400 ng.h/mL
Estimate against measurement, compound 3: 3.6-fold (0.55 log units) above; measured number below the stated range.
By their numbers in this assay, from the lowest: compounds 1 and 3 (each within the scatter of the next); then compound 2.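

In this assay, among these compounds, cyano in place of bromo on this aromatic carbon gives an 8.5-fold lower number from compound 2 to compound 3 (0.93 log units; beyond the scatter), the first reading of this change on its own, and it is beyond the scatter. With cyano held in place, the group of 12 heavy atoms in place of the group of 10 heavy atoms gives a 1.3-fold higher number from compound 1 to compound 3 (0.10 log units; within the scatter), so the wide gap between compound 1 and compound 2 tracks the bromo to cyano change rather than this second difference. No measurement shown bears on why exposure follows this group.

Bromo appears only with the group of 12 heavy atoms, so whether the same step holds with the group of 10 heavy atoms remains open. On these data alone, how a chloro group or a carboxylic acid on this aromatic carbon would read in this assay also remains open.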